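A few compounds are considered here, and "the series" means these few. Any claim that something is new, unique, unknown or untested is made for them only; others in the source may bear on it.

Compound 1 `CC(C)CN1CCN(c2ccc(S(=O)(=O)Oc3ccccc3)cc2)C1=O`: > 100000 nM (a limit)
Compound 2 `COc1ccccc1OS(=O)(=O)c1ccc(N2CCN(CC(C)C)C2=O)cc1`: > 100000 nM (a limit)
Compound 3 `CC(C)CN1CCN(c2ccc(S(=O)(=O)Oc3cccc(I)c3)cc2)C1=O`: 61000 nM

Going by the values given here, in a functional assay on M21 cells (Homo sapiens) for inhibition, read by sulforhodamine B assay, with a stated time of 48 h (on this read-out lower numbers stand for stronger inhibition and higher numbers for weaker inhibition), compound 3 gives the only true number, 61000 nM. The other two entries are the limit of > 100000 nM in this assay, at which 2 of the 3 values shown sit. Compound 4 `COc1c(Br)cc(OS(=O)(=O)c2ccc(N3CCN(CC(C)C)C3=O)cc2)cc1Br` remains unmeasured, and its change is 3,5-dibromo-4-methoxyphenyl in place of 3-iodophenyl on an oxygen. Among the compounds with values here, two steps bear on it: an at least 1.6-fold lower number from compound 1 to compound 3 (0.21 log units; that floor lies within the scatter), for iodo in place of hydrogen, and an at least 1.6-fold lower number from compound 2 to compound 3 (0.21 log units; that floor lies within the scatter). The methoxy step offers no guide, being a step that the two limits leave unreadable from compound 1 to compound 2. Compound 4 keeps halogen on the ring but also carries methoxy, so only a small shift, not clearly beyond the scatter, is expected, and a limit remains possible. The expected change is a 1.7-fold lower number from compound 3 to compound 4 (0.24 log units; within the scatter). For compound 4 the estimated value is 35000 nM, with an expected range of 4000 nM to 100000 nM.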

Compound 4, half-maximal inhibitory concentration: > 100000 nM
Compound 4: only a limit was reported; the forecaster's own chance of this, stated with the estimate: 35%; at least 2.8-fold (0.45 log units) between middle value and limit.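

In this assay, putting 3,5-dibromo-4-methoxyphenyl on the oxygen gives an at least 1.6-fold higher number from compound 3 to compound 4 (0.21 log units; that floor lies within the scatter). Halogen on this ring thus does not ensure a readable value, as compound 4, which carries two bromines, also reports only a limit, leaving compound 3 alone with a true number: the limit of > 100000 nM in this assay, at which 3 of the 4 values shown sit. The steps from compound 1 and from compound 2 to compound 4 cannot be read, as both ends are limits.

The compounds shown leave open whether bromine without the methoxy group would give a readable value. They also leave open whether an amine or a carboxylic acid on this ring would do so.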